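Dropping a Chain Methyl from Compound 1

The source may report more compounds than this note shows. Statements on the series, on what has been measured and on what is new or still open speak of the compounds shown alone.

Compound 1 `CC(CCCNCc1ccc(-c2csc3ccc(C#N)cc23)cc1)Nc1ccnc2ccccc12` carries a nitrile on its core, and it is measured here in a physicochemical assay for lipophilicity, at pH 10; a lower number here means a more polar compound, a higher number a more lipophilic compound. On this scale compound 1 gives 3.67. For the measured compounds named here, the only other measured compound, compound 2 `CN(CCCCNc1ccnc2ccccc12)Cc1ccc(-c2csc3ccc(F)cc23)cc1`, gives 3.98. Compound 1 therefore holds the lower of the two numbers, and the gap lies beyond the usual scatter of repeat measurements. However, the two compounds differ in more than one place, and their gap cannot be assigned to any single change.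

The next compound, compound 3 `N#Cc1ccc2scc(-c3ccc(CNCCCCNc4ccnc5ccccc45)cc3)c2c1`, differs from compound 1 in one place: hydrogen in place of methyl on a saturated chain carbon bound to a nitrogen on an aromatic ring and a saturated chain carbon. In words, it has hydrogen in place of methyl on a saturated chain carbon bound to a nitrogen on an aromatic ring and a saturated chain carbon. Going by the values given here, no measured pair shows this change directly, so the expectation rests on the loss of that single carbon alone. A small downward move is expected, with an estimated a number 0.27 log units lower from compound 1 to compound 3 (within the scatter), and this may not clear the scatter. The estimate for compound 3 is 3.4, within a range of 3 to 3.8.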

Compound 3, distribution coefficient: 3.67
Estimate against measurement, compound 3: 0.27 log units below; the measured number falls inside the stated range.
By their numbers in this assay, from the lowest: compounds 1 and 3 (each within the scatter of the next); then compound 2.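

For the compounds shown here, this is the first step in the set that changes only one place, so its outcome can be tied to a single group. In this assay the step reads no change at the digits printed from compound 1 to compound 3 (within the scatter) for hydrogen in place of methyl on a saturated chain carbon bound to a nitrogen on an aromatic ring and a saturated chain carbon. At this position, with the nitrile-bearing core of compound 1 held fixed, removing that one methyl therefore produces no difference that can be separated from repeat measurements, and no measurement available explains this result.

A single step at a single position cannot show whether a larger group on the same carbon, such as an ethyl, or a different kind of group, such as a hydroxymethyl or an amine, would move the number beyond the scatter. On these data alone, it also remains open whether the same swap from methyl to hydrogen would give this outcome on a core carrying fluorine, like that of compound 2, rather than a nitrile.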